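The source may hold more compounds than are shown below. What is called first, only, known or untested is meant among the compounds shown, and "the series" means these compounds.

In a functional assay on HepG2 cells (Homo sapiens) for cytotoxicity, read by MTT assay, with a stated time of 24 h (a higher number here means a weaker inhibitor, a lower number a stronger inhibitor), three compounds built on a shared core have been measured. Compound 1 `CN1C/C(=C\c2cccc([N+](=O)[O-])c2)C(=O)/C(=C/c2ccccc2F)C1` gives 1080 nM, compound 2 `COc1cc(/C=C2\CN(C)C/C(=C\c3ccc(C#N)cc3)C2=O)cc(OC)c1OC` gives 1140 nM, and compound 3 `CN1C/C(=C\c2ccc(F)cc2)C(=O)/C(=C/c2cccc([N+](=O)[O-])c2)C1` gives 9340 nM, the highest number of the three and so the weakest inhibitor here.

The next compound, compound 4 `CN1C/C(=C\c2ccc(Br)cc2)C(=O)/C(=C/c2cccc([N+](=O)[O-])c2)C1`, differs from compound 3 at a single place: bromo in place of fluoro on an aromatic carbon. Put simply, this is bromo in place of fluoro on an aromatic carbon, para to a large group, turning 4-fluorophenyl into 4-bromophenyl.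

For the measured compounds named here, only one measured step bears on this change. Putting 4-fluorophenyl in place of 2-fluorophenyl gave an 8.6-fold higher number from compound 1 to compound 3 (0.94 log units; beyond the scatter), so a change on this part of the molecule can register clearly in this assay. Going by the values given here, that step moves a fluoro, however, and does not exchange it for another atom, and no measured pair shows such an exchange. A smaller step is therefore expected here, with a slight lean towards a lower number, since compound 3 at 9340 nM sits at the top of the measured values. The expected change is a 1.6-fold lower number from compound 3 to compound 4 (0.19 log units; within the scatter). For compound 4 the estimated value is 6000 nM, with an expected range of 1800 nM to 20000 nM.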

Compound 4, half-maximal inhibitory concentration: 8800 nM
For compound 4 the middle estimate is 1.5-fold (0.17 log units) below the measured one, within the range that was stated.
By their numbers in this assay, from the lowest: compounds 1 and 2 (each within the scatter of the next); then compounds 4 and 3 (each within the scatter of the next).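

In this assay, exchanging fluoro for bromo on an aromatic carbon, para to a large group, gives a 1.1-fold lower number from compound 3 to compound 4 (0.03 log units; within the scatter) and so leaves the two compounds indistinguishable, whereas the earlier step only moved a fluoro and could not show what a different atom does at this place. The larger gap seen earlier also returns with the new atom: 4-bromophenyl in place of 2-fluorophenyl gives an 8.1-fold higher number from compound 1 to compound 4 (0.91 log units; beyond the scatter), a step much like an 8.6-fold higher number from compound 1 to compound 3 (0.94 log units; beyond the scatter), so among these compounds the higher number comes with either 4-fluorophenyl or 4-bromophenyl, not with fluoro alone. Nothing at hand explains why fluoro and bromo match here.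

From the compounds shown here alone, it remains open whether an amine or a carboxylic acid in this same place would also leave the number unchanged, or would shift it as clearly as the earlier step did. Going by these compounds, it is equally open whether fluoro and bromo would still match if the other side of the shared core carried a different group.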